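The source may hold more compounds than are shown below. What is called first, only, known or untested is meant among the compounds shown, and "the series" means these compounds.

Three compounds share the core of compound 1 `CCCCCCNC(=O)n1cc(CC)c(=O)[nH]c1=O` and differ only in the small group on one aromatic carbon. In an assay on HEK293 cells for inhibition of acid ceramidase (Rattus norvegicus), read by LC-MS, with a stated time of 30 min (on this read-out higher numbers stand for weaker inhibition and lower numbers for stronger inhibition), compound 1 gives 733 nM; compound 2 `CCCCCCNC(=O)n1cc(OC)c(=O)[nH]c1=O` gives 1100 nM; compound 3 `CCCCCCNC(=O)n1cc(-c2ccccc2)c(=O)[nH]c1=O` gives 177 nM. Compound 2 stands highest of the three numbers, though its gap to compound 1 is small: a 1.5-fold higher number from compound 1 to compound 2 (0.18 log units; within the scatter). For the measured compounds named here, the only steps beyond the scatter lead to the phenyl compound: a 6.2-fold lower number from compound 2 to compound 3 (0.79 log units; beyond the scatter) and a 4.1-fold lower number from compound 1 to compound 3 (0.62 log units; beyond the scatter).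

Compound 4 `CCCCCCNC(=O)n1cc(NC)c(=O)[nH]c1=O` differs from compound 2 by methylamino in place of methoxy on an aromatic carbon. Going by the values given here, the steps that bear on it are the exchange of ethyl for methoxy, which stayed within the scatter, and the exchange for phenyl, which was modest. Among the compounds with values here, the one small-group swap measured so far did not move this assay beyond the scatter, and no measured compound carries a methylamino group on that aromatic carbon. For compound 4 the expected step is therefore within the scatter, namely a 1.1-fold lower number from compound 2 to compound 4 (0.04 log units; within the scatter). Compound 4 is estimated at 1000 nM, with a range from 400 nM to 2500 nM.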

Compound 4, half-maximal inhibitory concentration: 3400 nM
Estimate against measurement, compound 4: 3.4-fold (0.53 log units) below; measured number above the stated range.
By their numbers in this assay, from the lowest: compound 3; then compounds 1 and 2 (each within the scatter of the next); then compound 4.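

In this assay, small groups on this aromatic carbon are not interchangeable: methylamino in place of methoxy gives a 3.1-fold higher number from compound 2 to compound 4 (0.49 log units; beyond the scatter) even though both groups have the same heavy-atom count, and methylamino carries a hydrogen-bond donor where methoxy carries none. Against the other small group, the exchange gives a 4.6-fold higher number from compound 1 to compound 4 (0.67 log units; beyond the scatter), so compound 4 sits apart from both compound 1 and compound 2, and the spread across the position widens to a 19-fold higher number from compound 3 to compound 4 (1.28 log units; beyond the scatter). Nothing measured here accounts for the change from methoxy to methylamino.

Going by these compounds, whether the higher number goes with the hydrogen-bond donor or with the nitrogen itself stays open. A dimethylamino group or an unsubstituted amine on the same carbon would bear on that, and a substituted phenyl would show whether the lower number of compound 3 can be taken further.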